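The source may hold more compounds than are shown below. What is called first, only, known or untested is meant among the compounds shown, and "the series" means these compounds.

Working notes on the series. The shared core carries a pendant aryl ring whose substituent is varied: compound 1 `CCC(C)(C)Cc1c[nH]c(CCc2ccc(-c3cccc(N)n3)cc2)n1` bears a 6-aminopyridin-2-yl group, compound 2 `CCC(C)(C)Cc1c[nH]c(CCc2ccc(-c3cccnc3)cc2)n1` a pyridin-3-yl group and compound 3 `CCC(C)(C)Cc1c[nH]c(CCc2ccc(-n3ncnn3)cc2)n1` a 2H-tetrazol-2-yl group. In a functional assay on HEK293 cells for agonist activity at Bombesin receptor subtype-3 (Mus musculus), read by luminescence and calcium flux, with a stated time of 10 min (on this read-out higher numbers stand for an effect only at larger amounts of compound and lower numbers for an effect already at smaller amounts), compound 1 gives 119 nM, compound 2 gives 97 nM and compound 3 gives 99 nM. The number for compound 1 is the highest of the three, but the steps of a 1.2-fold lower number from compound 1 to compound 2 (0.09 log units; within the scatter) and a 1.2-fold lower number from compound 1 to compound 3 (0.08 log units; within the scatter) lie within the scatter, as does a 1.0-fold higher number from compound 2 to compound 3 (0.01 log units; within the scatter); the three substituents are not distinguished by this assay.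

Compound 4 `CCC(C)(C)Cc1c[nH]c(CCc2ccc(-c3cccc(C)n3)cc2)n1` is not yet measured. Relative to compound 1 the change is methyl in place of amino on an aromatic carbon. For the measured compounds named here, the steps that bear on it are a 1.2-fold lower number from compound 1 to compound 2 (0.09 log units; within the scatter) and a 1.2-fold lower number from compound 1 to compound 3 (0.08 log units; within the scatter), which exchanged the whole 6-aminopyridin-2-yl group without any step beyond the scatter; exchanging one heavy atom at the same place is expected to do no more. The step expected in this assay is therefore a 1.1-fold lower number from compound 1 to compound 4 (0.03 log units; within the scatter), with no direction beyond the scatter. Compound 4 is expected to give 110 nM, with a range from 50 nM to 250 nM.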

Compound 4, half-maximal effective concentration: 106 nM
Compound 4: the middle estimate sits 1.0-fold (0.02 log units) above what was measured; the measured number falls inside the stated range.
By their numbers in this assay, from the lowest: compounds 2, 3, 4 and 1 (each within the scatter of the next).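

At this place, on an aromatic carbon next to the ring nitrogen, methyl in place of amino brings no readable change in this assay, with a 1.1-fold lower number from compound 1 to compound 4 (0.05 log units; within the scatter). The amino group, with its hydrogen-bond donor and acceptor, is therefore not required for the number seen here, and the 6-methylpyridin-2-yl compound cannot be told apart from the other two, with a 1.1-fold higher number from compound 3 to compound 4 (0.03 log units; within the scatter) and a 1.1-fold higher number from compound 2 to compound 4 (0.04 log units; within the scatter). No evidence at hand gives a reason for this lack of separation.

From the compounds shown here alone, whether a carboxylic acid or a longer chain such as n-butyl at this place would move the number beyond the scatter remains open. Also open is whether any change here matters at all, since every step among these four compounds lies within the scatter.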